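Fluorine on the phenyl ring of a quinoline amide series

This account rests on a few compounds, and the source may have more. Where it says the series, first, only, none or still open, it means among the compounds named here.

Compound 1 `COc1cc2c(Oc3ccc(NC(=O)c4nn(-c5ccccc5)c(=O)c5ccccc45)cc3F)ccnc2cc1OCCCN1CCN(C)CC1` is the parent. In a functional assay on MDA-MB-231 cells (Homo sapiens) for cytotoxicity, read by MTT assay, with a stated time of 72 h (a lower number here means a stronger inhibitor, a higher number a weaker inhibitor), compound 1 gives 1580 nM. Compound 2 `COc1cc2c(Oc3ccc(NC(=O)c4nn(-c5ccccc5F)c(=O)c5ccccc45)cc3F)ccnc2cc1OCCCN1CCN(C)CC1` carries fluoro in place of hydrogen on an aromatic carbon and in this assay compound 2 gives 1050 nM, so that a 1.5-fold lower number from compound 1 to compound 2 (0.18 log units; within the scatter). Compound 3 `COc1cc2c(Oc3ccc(NC(=O)c4nn(-c5ccccc5)c(=O)c5ccccc45)cc3F)ccnc2cc1OCCCN1CCC(C)CC1` differs from compound 1 by 4-methylpiperidin-1-yl in place of 4-methylpiperazin-1-yl on a saturated chain carbon, three bonds along the chain from an oxygen on an aromatic ring; in this assay compound 3 gives 1480 nM, and a 1.1-fold lower number from compound 1 to compound 3 (0.03 log units; within the scatter). Compound 4 `COc1cc2c(Oc3ccc(NC(=O)c4nn(-c5ccc(F)cc5)c(=O)c5ccccc45)cc3F)ccnc2cc1OCCCN1CCC(C)CC1` differs from compound 3 by fluoro in place of hydrogen on an aromatic carbon. This is the same kind of change as from compound 1 to compound 2, but not the same change. There the fluoro sits ortho to a large group, while here it sits para to a large group. The step from compound 3 to compound 4 is expected to be small, roughly a 1.2-fold lower number from compound 3 to compound 4 (0.09 log units; within the scatter), because the earlier step was a 1.5-fold lower number from compound 1 to compound 2 (0.18 log units; within the scatter). Compound 4 is therefore estimated at 1200 nM, between 500 nM and 3000 nM.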

Compound 4, half-maximal inhibitory concentration: 660 nM
Compound 4: the middle estimate sits 1.8-fold (0.26 log units) above what was measured; low and high end bracket the measured number.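

In this assay, going from phenyl to 4-fluorophenyl gives a 2.2-fold lower number from compound 3 to compound 4 (0.35 log units; beyond the scatter), a modest step. Set beside the earlier fluoro step on the other core, the two steps agree within the scatter: the same change on two cores in this assay, a 1.5-fold lower number (0.18 log units; within the scatter) from compound 1 to compound 2 and a 2.2-fold lower number (0.35 log units; beyond the scatter) from compound 3 to compound 4, 1.5-fold (0.17 log units) apart, within the scatter of two such steps. This does not show that the change carries over unaltered, as the fluoro stands at a different place on the phenyl ring in each step, so the effect of its place cannot be told apart from the effect of the core.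

The compounds shown leave open how 4-fluorophenyl behaves together with the 4-methylpiperazin-1-yl group. They also leave open what a chloro or methoxy group would do in place of the fluoro.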